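The source may hold more compounds than are shown below. What is called first, only, known or untested is meant among the compounds shown, and "the series" means these compounds.

Compound 1 `Fc1ccc(-c2nn3c(NC4CCCC4)cccc3c2-c2ccnc(NC3CCCC3)n2)cc1` gives > 160000 nM in an ADME assay on Vero cells (Chlorocebus sabaeus) for cytotoxicity; a higher number here means that more compound is tolerated, a lower number that less compound is tolerated; this value is a limit of the assay and not a number.
Compound 2 `Fc1ccc(-c2nn3c(NC4CCCC4)nccc3c2-c2ccnc(NC3CCCC3)n2)cc1` gives > 40000 nM in this assay; this too is a limit of the assay.
Compound 3 `Fc1ccc(-c2nn3c(N4CCCCC4)nccc3c2-c2ccnc(NC3CCCC3)n2)cc1` gives > 40000 nM in this assay; again only a limit of the assay is known.

Compound 3 therefore stands at the limit of > 40000 nM in this assay, at which 2 of the 3 values shown sit, and nothing more precise is known for it; the limit of > 160000 nM in this assay, at which 1 of the 3 values shown sits, covers the remaining value. Going by the values given here, the only step among measured compounds, a step that the two limits leave unreadable from compound 2 to compound 3, is unreadable, since both ends sit at limits. Compound 4 `Fc1ccc(-c2nn3c(N4CCCC4)nccc3c2-c2ccnc(NC3CCCC3)n2)cc1` differs from compound 3 by pyrrolidin-1-yl in place of piperidin-1-yl on an aromatic carbon. Among the compounds with values here, no measured step bears readably on this change, so the account has no basis for a step in this assay beyond the scatter in either direction, and the most likely outcome is that compound 4 also sits at a limit. The step from compound 3 to compound 4 is therefore expected to be a step that the limit leaves unreadable from compound 3 to compound 4. Compound 4 is estimated at 80000 nM in this assay, within a range from 20000 nM to 320000 nM.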

Compound 4, half-maximal cytotoxic concentration: > 40000 nM
Compound 4: only a limit was reported; the forecaster's own chance of this, stated with the estimate: 80%; the middle value does not contradict the limit.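

In this assay, going by these compounds alone, compound 4 is known only as a limit of the assay, like compound 2 and compound 3, so no step from either of them to compound 4 can be read. The compounds shown leave open whether pyrrolidin-1-yl, piperidin-1-yl and cyclopentylamino differ at all in this read-out.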